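Cytotoxicity of aryl amides on a shared chromone core

A few compounds are considered here, and "the series" means these few. Any claim that something is new, unique, unknown or untested is made for them only; others in the source may bear on it.

Measured compounds:
- compound 1, `O=C(/C=C/c1coc2cc(O)ccc2c1=O)NCc1ccc(F)cc1`: 357000 nM
- compound 2, `COc1ccc2c(=O)c(/C=C/C(=O)Nc3ccc(Cl)cc3)coc2c1`: 272000 nM
- compound 3, `O=C(/C=C/c1coc2cc(O)ccc2c1=O)Nc1ccccc1`: 821000 nM

In an ADME assay on HepG2 2.2.15 cells (Homo sapiens) for cytotoxicity, read by MTT assay, with stated times of 48 h and 9 days (a lower number here means that less compound is tolerated, a higher number that more compound is tolerated), compound 2 gives the lowest of the three numbers. Its nearest neighbour is compound 1, whose value lies within the scatter of that of compound 2, while compound 3 stands furthest away with a higher value, a gap that is beyond the scatter. Compound 4, `COc1cccc(NC(=O)/C=C/c2coc3cc(OC)ccc3c2=O)c1`, is not yet measured. It differs from compound 2 in one place: 3-methoxyphenyl in place of 4-chlorophenyl on an amide-type nitrogen. Going by the values given here, the only measured step that touches the same position is the one from compound 1 to compound 3, a 2.3-fold higher number from compound 1 to compound 3 (0.36 log units; beyond the scatter), which swapped a substituted benzyl for a bare phenyl on the amide nitrogen; it is a modest step and only loosely comparable, since here one substituted phenyl replaces another. Among the compounds with values here, no step among the measured compounds exchanges a chlorine for a methoxy group. The step for compound 4 is therefore expected to be small, plausibly within or just beyond the scatter and, if anything, upward, so compound 4 is estimated at 350000 nM with a range from 150000 nM to 800000 nM, corresponding to an expected step of a 1.3-fold higher number from compound 2 to compound 4 (0.11 log units; within the scatter).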

Compound 4, half-maximal cytotoxic concentration: 1130000 nM
Beside the measured number, compound 4's estimate is 3.2-fold (0.51 log units) below it; the whole stated range lies below it.
By their numbers in this assay, from the lowest: compounds 2 and 1 (each within the scatter of the next); then compounds 3 and 4 (each within the scatter of the next).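

In this assay, putting 3-methoxyphenyl in place of 4-chlorophenyl on the amide-type nitrogen gives a 4.2-fold higher number from compound 2 to compound 4 (0.62 log units; beyond the scatter) and so shows that more compound is tolerated after this exchange. Going by these compounds alone, the only earlier step at this nitrogen, a 2.3-fold higher number from compound 1 to compound 3 (0.36 log units; beyond the scatter) and replacing 4-fluorobenzyl with phenyl, changed the kind of group attached; the new step shows that the number also moves beyond the scatter when a substituted phenyl stays in place and only its substitution changes. No measurement shown here accounts for the step.

The compounds shown leave open whether losing the chlorine, gaining the methoxy group or the different place of the substituent carries the step. They also leave open how the number would respond to an amine or a carboxylic acid on the same phenyl ring.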